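The source may report more compounds than this note shows. Statements on the series, on what has been measured and on what is new or still open speak of the compounds shown alone.

Measured so far in a functional assay on CCRF-CEM cells (Homo sapiens) for inhibition, read by MTT assay, with a stated time of 72 h; on this read-out lower numbers stand for stronger inhibition and higher numbers for weaker inhibition:
- compound 1 `C=C(Br)C(=O)Nc1cccc(/C=C/C(=O)Nc2cccc(F)c2)c1` gives 26000 nM in this series
- compound 2 `C=C(Br)C(=O)Nc1cccc(/C=C/C(=O)Nc2ccc(C)cc2)c1` gives 270 nM in this series

Compound 2 holds the lower of the two numbers. Still unmeasured is compound 3 `C=C(Br)C(=O)Nc1cccc(/C=C/C(=O)Nc2ccc(SC(F)(F)F)cc2)c1` with (trifluoromethyl)sulfanyl in place of methyl on an aromatic carbon and the rest of compound 2 unchanged.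

Among the compounds with values here, one measured step bears on this: a 96-fold lower number from compound 1 to compound 2 (1.98 log units; beyond the scatter) with 4-methylphenyl in place of 3-fluorophenyl on an amide-type nitrogen. That step was large and beyond the scatter, so a swap at this end of the molecule can shift the number far. Within the data shown here, no measured compound carries the new group, which leaves the direction weakly supported. A moderate rise in this assay is expected, smaller than that step. The expected change is a 2.6-fold higher number from compound 2 to compound 3 (0.41 log units; beyond the scatter) as a working estimate. For compound 3 the estimated value is 700 nM with 120 nM to 5000 nM as the expected range.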

Compound 3, half-maximal inhibitory concentration: 15300 nM
Compound 3: middle estimate off by 22-fold (1.34 log units), on the low side; the whole stated range lies below it.
By their numbers in this assay, from the lowest: compound 2; then compounds 3 and 1 (each within the scatter of the next).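

With the rest of compound 2 unchanged, (trifluoromethyl)sulfanyl in place of methyl on the aromatic carbon para to a large group gives a 57-fold higher number from compound 2 to compound 3 (1.75 log units; beyond the scatter) in this assay. The earlier step changed the group and its place on this ring together, whereas this one keeps the place fixed, so a swap of group alone can cost most of the inhibition seen with methyl. Nothing available on these compounds gives a reason for this loss.

The compounds shown leave open whether the size of the entering group, its sulfur atom or its fluorine atoms matter most, since only methyl and (trifluoromethyl)sulfanyl are compared at this carbon. An ethyl group, a methoxy group, a chlorine atom or an amine there would show how narrowly the low number depends on methyl.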